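This account rests on a few compounds, and the source may have more. Where it says the series, first, only, none or still open, it means among the compounds named here.

Compound 1 `Nc1cc(N)c2nc(-c3ccccc3)c(Oc3ccc(Cl)c(Cl)c3)nc2c1` is measured in a functional assay on OVCAR-3 cells (Homo sapiens) for inhibition, read by sulforhodamine B assay, with a stated time of 48 h (a lower number here means a stronger inhibitor of growth, a higher number a weaker inhibitor of growth), where compound 1 gives 26900 nM. Compound 2 `COc1ccc(CNc2nc3cc(N)cc(N)c3nc2-c2ccccc2)cc1` gives 7760 nM in this assay. Of these two numbers, compound 1 has the higher one, and the gap to compound 2 lies beyond the scatter.

Compound 3 `Nc1cc(N)c2nc(-c3ccccc3)c(Oc3ccc(F)cc3)nc2c1` differs from compound 1 by 4-fluorophenyl in place of 3,4-dichlorophenyl on an oxygen on an aromatic ring. Among the measured compounds shown here, no measured pair shows this exchange, so there is nothing to set its size by. The step of a 1.1-fold higher number from compound 1 to compound 3 (0.05 log units; within the scatter) is expected to be small, with no clear direction beyond the scatter. Compound 3 is therefore estimated at 30000 nM, within a range from 10000 nM to 90000 nM.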

Compound 3, concentration for total growth inhibition: 41700 nM
For compound 3 the middle estimate is 1.4-fold (0.14 log units) below the measured one; low and high end bracket the measured number.
By their numbers in this assay, from the lowest: compound 2; then compounds 1 and 3 (each within the scatter of the next).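

In this assay, placing 4-fluorophenyl where 3,4-dichlorophenyl stood on the oxygen gives a 1.6-fold higher number from compound 1 to compound 3 (0.19 log units; within the scatter), so these two halogen-bearing rings cannot be told apart at this position. Among the compounds shown here, this single exchange is the first direct test of the position, and it shows that losing both chlorines and gaining one fluorine leaves the growth-inhibition number without a clear change. No measured evidence bears on this result.

Both groups shown here are halogen-bearing phenyl rings. As far as these compounds go, whether a phenyl ring carrying an amine or a carboxylic acid, or a longer alkyl chain on the oxygen, would shift the number beyond the scatter remains open.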